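From methoxy to bromo in an antiproliferative series

This account rests on a few compounds, and the source may have more. Where it says the series, first, only, none or still open, it means among the compounds named here.

Values measured in a functional assay on HCT-116 cells (Homo sapiens) for antiproliferative activity, read by MTT assay, with a stated time of 72 h (on this read-out higher numbers stand for weaker inhibition and lower numbers for stronger inhibition), are these
Compound 1 `CCOC(=O)c1csc2nc(CN3CCN(C)CC3)c(-c3ccc(C)cc3)n12` gives 61000 nM in this series
Compound 2 `CCOC(=O)c1csc2nc(CN3CCN(C)CC3)c(-c3ccc(OC)cc3)n12` gives 44600 nM in this series
Compound 3 `CCOC(=O)c1csc2nc(CN3CCN(Cc4ccccc4)CC3)c(-c3ccc(OC)cc3)n12` gives 19600 nM in this series

Compound 2 at 44600 nM cannot be separated from compound 1 (a 1.4-fold lower number from compound 1 to compound 2 (0.14 log units; within the scatter)) and has the higher number against compound 3 (a 2.3-fold lower number from compound 2 to compound 3 (0.36 log units; beyond the scatter)) in this small set.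

Compound 4 `CCOC(=O)c1csc2nc(CN3CCN(C)CC3)c(-c3ccc(Br)cc3)n12` has not been measured. It differs from compound 2 by bromo in place of methoxy on an aromatic carbon and in nothing else. The nearest evidence is the change of group at that same carbon (a 1.4-fold lower number from compound 1 to compound 2 (0.14 log units; within the scatter)) which stayed within the scatter. The other step (a 2.3-fold lower number from compound 2 to compound 3 (0.36 log units; beyond the scatter)) concerns phenyl in place of hydrogen on a saturated chain carbon and says nothing about this carbon. For the measured compounds named here, no bromo compound has a measured value, so the expectation rests on one small step.

A step beyond the scatter is not expected, and the estimated change (a 1.1-fold lower number from compound 2 to compound 4 (0.05 log units; within the scatter)) has no firm direction in this assay here. Compound 4 is expected at 40000 nM with an estimated range from 18000 nM to 85000 nM in this read-out.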

Compound 4, half-maximal inhibitory concentration: 93600 nM
Estimate against measurement, compound 4: 2.3-fold (0.37 log units) below; measured number above the stated range.
By their numbers in this assay, from the lowest: compound 3; then compounds 2, 1 and 4 (each within the scatter of the next, the first and the last beyond it).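

For the compounds shown here, at this carbon, in this assay, the change from 4-methoxyphenyl to 4-bromophenyl gives the first step at this position that lies beyond the scatter (a 2.1-fold higher number from compound 2 to compound 4 (0.32 log units; beyond the scatter)), so the choice of group here can register in the read-out, although the step is modest. Compound 1 and compound 4 cannot be separated (a 1.5-fold higher number from compound 1 to compound 4 (0.19 log units; within the scatter)), and compound 1 also lies within the scatter of compound 2, so only the methoxy and bromo compounds stand apart, with the methyl compound unresolved from either. Nothing available explains this difference between methoxy and bromo.

On these data alone, it remains open whether a chloro, fluoro, hydroxyl or amino group on this carbon would fall nearer the methoxy or the bromo compound. As far as these compounds go, it also remains open whether the phenyl step seen from compound 2 to compound 3 would recur in a compound carrying 4-bromophenyl.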